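The compounds below may be only part of what the source reports. "The series", "measured", "known", "first", "only" and "open" are said of these compounds alone.

In a functional assay on BaF3 cells (Mus musculus) for antiproliferative activity, read by CCK-8 assay and cell counting, with a stated time of 76 h; on this read-out higher numbers stand for weaker inhibition and lower numbers for stronger inhibition:
Compound 1 `COc1cc2nccc(Oc3ccc(Nc4nn(C)cc4C(=O)NCc4ccccc4)cc3)c2cc1C(N)=O`: > 10000 nM, a limit.
Compound 2 `COc1cc2nccc(Oc3ccc(Nc4nn(C)cc4C(=O)Nc4ccccc4)cc3)c2cc1C(N)=O`: > 10000 nM, a limit.
Compound 3 `COc1cc2nccc(Oc3ccc(Nc4nn(C)cc4C(=O)N4CCCC5CCCCC54)cc3)c2cc1C(N)=O`: 4330 nM.

Only compound 3 gives an actual number, and the other two sit at the limit of > 10000 nM in this assay, at which 2 of the 3 values shown sit. Compound 4 `COc1cc2nccc(Oc3ccc(Nc4nn(C)cc4C(=O)NC4CCCC4)cc3)c2cc1C(N)=O` differs from it on a carbonyl carbon: a group of 6 heavy atoms (5 carbon, 1 nitrogen; one five-membered non-aromatic ring of carbon only) in place of a group of 10 heavy atoms (9 carbon, 1 nitrogen; one six-membered non-aromatic ring of carbon only, one six-membered non-aromatic ring with 1 hetero atom), on a carbonyl carbon. Among the compounds with values here, two measured steps bear on this, an at least 2.3-fold lower number from compound 1 to compound 3 (0.36 log units; beyond the scatter) and an at least 2.3-fold lower number from compound 2 to compound 3 (0.36 log units; beyond the scatter). Within the data shown here, both end on the group that leaves here, and cyclopentylamino brings back an amide hydrogen like the one in compound 1 and compound 2, so a move of similar size toward weaker inhibition is expected. The expected step is a 2.1-fold higher number from compound 3 to compound 4 (0.32 log units; beyond the scatter). For compound 4 the estimated value is 9000 nM, with an expected range from 3000 nM to 25000 nM.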

Compound 4, half-maximal inhibitory concentration: > 10000 nM
Compound 4: a limit, no number; the forecaster's own chance of this, stated with the estimate: 50%; at least 1.1-fold (0.04 log units) between middle value and limit.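

Cyclopentylamino on the carbonyl carbon brings an at least 2.3-fold higher number from compound 3 to compound 4 (0.36 log units; beyond the scatter) in this assay, so a non-aromatic ring on the amide nitrogen does not by itself keep the inhibition of compound 3. Compound 4 stands at a limit, and the steps from compound 1 and from compound 2 to it cannot be read. Of the compounds shown, only compound 3 lacks the amide hydrogen and gives a number, and the comparison with the others ends at this limit: the limit of > 10000 nM in this assay, at which 3 of the 4 values shown sit.

The change alters both the amide hydrogen and the size of the group, and the compounds shown do not separate the two. On these data alone, how a piperidine or a morpholine would behave on this carbonyl carbon remains open.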